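Phenyl for methyl at the carbonyl of compound 1

This account rests on a few compounds, and the source may have more. Where it says the series, first, only, none or still open, it means among the compounds named here.

The series is followed in a functional assay on MCF7 cells (Homo sapiens) for inhibition, read by MTT assay, with a stated time of 48 h; on this read-out lower numbers stand for stronger inhibition and higher numbers for weaker inhibition. Compound 1 `COc1cc(-c2cc(/C=C/C(C)=O)[nH]n2)cc(OC)c1OC` gives 20100 nM, the highest number among the three measured compounds. Compound 2 `COc1cc(-c2cc(/C=C3\CCc4ccccc4C3=O)[nH]n2)cc(OC)c1OC` gives 8500 nM, a lower number than compound 1 by a margin beyond the scatter. Compound 3 `COc1ccc(-c2cc(/C=C/C(=O)c3ccc(OC)c(OC)c3)[nH]n2)cc1` gives 500 nM, the lowest number of the three and far beyond the scatter from compound 1; compound 3 differs from compound 1 in more than one place, so no single step can be read from that pair.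

Compound 4 `COc1cc(-c2cc(/C=C/C(=O)c3ccccc3)[nH]n2)cc(OC)c1OC` has not been measured. It differs from compound 1 in one place: phenyl in place of methyl on a carbonyl carbon. Among the measured compounds shown here, no measured pair shows exactly this change on an otherwise identical core. What the numbers do show is that compound 3, which also carries a phenyl on its carbonyl carbon, gives 500 nM, while compound 1, with methyl there, gives 20100 nM.

Relative to compound 1, compound 4 is therefore expected to show a lower number, the estimated step being a 6.7-fold lower number from compound 1 to compound 4 (0.83 log units; beyond the scatter), expected to lie beyond the scatter. The estimate for compound 4 in this assay is 3000 nM, with a range from 800 nM to 12000 nM.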

Compound 4, half-maximal inhibitory concentration: 2100 nM
Compound 4: middle estimate off by 1.4-fold (0.15 log units), on the high side; the measured number falls inside the stated range.
By their numbers in this assay, from the lowest: compound 3; then compound 4; then compound 2; then compound 1.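

In this assay, among the compounds shown here, the change from acetyl to benzoyl on the core of compound 1 gives the first reading at this position from a pair that differs in one place only: a 9.6-fold lower number from compound 1 to compound 4 (0.98 log units; beyond the scatter). The group on the carbonyl carbon therefore has a measurable bearing on the number in this series, and the shift comes from a plain phenyl, a six-membered aromatic ring of carbon only, with no hydrogen-bond donor or acceptor entering in the swap. No measurement at hand speaks to the reason for this step.

Still open, going by these compounds, is whether the gain needs an aromatic ring at all or would also follow from a cyclohexyl ring or a longer chain such as n-butyl on the carbonyl carbon, and whether a pyridyl ring or a phenyl bearing an amine or a carboxylic acid would keep, extend or lose it. Also open is whether a step of this size carries over to the core of compound 3, where the methoxy groups differ and no matching acetyl partner is shown.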